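Meta substituent swap: bromo in place of isopropyl

The compounds below may be only part of what the source reports. "The series", "measured", "known", "first", "only" and "open" are said of these compounds alone.

Measured so far in a functional assay on RCC4 cells (Homo sapiens) for inhibition, read by XTT assay, with a stated time of 4 days; on this read-out higher numbers stand for weaker inhibition and lower numbers for stronger inhibition:
compound 1 `CC(C)c1cccc(Nc2nc(-c3ccncc3)cs2)c1` — 17400 nM
compound 2 `Cc1cccc(Nc2nc(-c3ccnc(-c4cccc(F)n4)c3)cs2)c1` — > 40000 nM; 12600 nM (2 entries)
compound 3 `Cc1cccc(Nc2nc(-c3ccnc(OCCCN(C)C)c3)cs2)c1` — 6000 nM; 6030 nM (2 entries)

Going by the values given here, compound 1 is the only compound with a single entry; compound 2 and compound 3 each carry two. Of compound 2, one entry is a limit of the assay and not a number (the several entries of compound 2 in this assay, > 40000 nM; 12600 nM (2 entries)). Compound 3 gives two entries that agree closely (the several entries of compound 3 in this assay, 6000 nM; 6030 nM (2 entries)). Against those, compound 1 stands weaker than compound 3, while its value and the numeric entry of compound 2 lie within the usual scatter of each other.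

Compound 4 `Brc1cccc(Nc2nc(-c3ccncc3)cs2)c1` differs from compound 1 by bromo in place of isopropyl on an aromatic carbon. Among the compounds with values here, no measured pair in this set carries the same change, so nothing here sets the size of the step. With both groups being small substituents at the same position of the shared core, the change from compound 1 to compound 4 is expected to stay within the scatter, at a 1.2-fold lower number from compound 1 to compound 4 (0.06 log units; within the scatter). On this basis compound 4 is estimated at 15000 nM, within 5000 nM to 45000 nM.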

Compound 4, half-maximal inhibitory concentration: 40700 nM
For compound 4 the middle estimate is 2.7-fold (0.43 log units) below the measured one; the range from low to high includes it.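

Bromo in place of isopropyl on an aromatic carbon gives a 2.3-fold higher number from compound 1 to compound 4 (0.37 log units; beyond the scatter) in this assay and is the first readable step between two compounds that differ in one place. The position therefore does not tolerate this exchange without change: compound 4 is the weaker of the pair, although neither group brings a hydrogen-bond donor, a hydrogen-bond acceptor, a ring or a net charge. The bromo group has 1 heavy atom against 3 for isopropyl, but a single pair cannot tie the step to that count, and no measured evidence here bears on the reason for the loss.

A single exchange gives neither a trend nor a ranking of groups at this position on the shared core. A carboxylic acid, a primary amine or a longer alkyl chain in the same place would show whether the position responds more widely than this one modest step suggests.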